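Amino for chloro on the core of compound 1

The source may hold more compounds than are shown below. What is called first, only, known or untested is meant among the compounds shown, and "the series" means these compounds.

Measured so far:
compound 1 `ClCc1ccccc1Cn1cnc2c(Cl)nc(Cl)nc21` — 150 nM
compound 2 `ClCc1ccc(Cn2cnc3nc(Cl)nc(Cl)c32)cc1` — 1620 nM

In a functional assay on LOX IMVI cells (Homo sapiens) for cytotoxicity, read by sulforhodamine B assay, with a stated time of 48 h (a higher number here means a weaker inhibitor of growth, a lower number a stronger inhibitor of growth), compound 1 holds the lower of the two numbers; compound 2 stands higher, beyond the scatter. Going by the values given here, no pair differing in one place has been measured, so no step size is known from the data.

Compound 3 `Nc1nc(Cl)c2ncn(Cc3ccccc3CCl)c2n1` carries the change (amino in place of chloro on an aromatic carbon), in words an amino in place of chloro on an aromatic carbon. Without a measured step of this kind, a modest weakening is expected, by a 2.7-fold higher number from compound 1 to compound 3 (0.43 log units; beyond the scatter). Compound 3 is estimated at 400 nM, between 100 nM and 1500 nM.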

Compound 3, concentration for 50% growth inhibition: 3890 nM
Beside the measured number, compound 3's estimate is 9.7-fold (0.99 log units) below it; the measured number lies above the stated range.
By their numbers in this assay, from the lowest: compound 1; then compound 2; then compound 3.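

In this assay, the position between two ring nitrogen atoms proves sensitive to this change: amino in place of chloro gives a 26-fold higher number from compound 1 to compound 3 (1.41 log units; beyond the scatter). Going by these compounds alone, as the only step measured on the core of compound 1, it shows that amino does not stand in for this chloro without a large loss of growth inhibition. No available evidence explains the loss. The compounds shown leave open whether a methoxy group, a methylamino group or a bromo group at this position would hold the growth inhibition of compound 1. They also leave open whether the same exchange would give a step of similar size on compound 2.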